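Working notes: purine benzamides, arylamino replacing methylpiperazine

The compounds below may be only part of what the source reports. "The series", "measured", "known", "first", "only" and "open" are said of these compounds alone.

Of the compounds shown here, two have numbers so far. Compound 1 `CN1CCN(c2nc(Cl)nc3c2ncn3Cc2ccc(C(=O)Nc3ccccc3N)cc2)CC1` and compound 2 `Nc1ccccc1NC(=O)/C=C/c1ccc(Cn2cnc3c(Nc4cccc(Cl)c4)nc(Cl)nc32)cc1` were both run in a functional assay on HCT-116 cells (Homo sapiens) for antiproliferative activity, read by CCK-8 assay, with a stated time of 72 h, tested at 2 uM; a higher number here means a stronger effect of the compound at the concentration tested, a lower number a weaker effect. Compound 1 gives 71.6% and stands highest of the two, while compound 2 gives 12.9%, a gap beyond the usual scatter. The two differ in more than one place, so no single step can be read from this pair.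

Compound 3 `Cc1ccc(Nc2nc(Cl)nc3c2ncn3Cc2ccc(C(=O)Nc3ccccc3N)cc2)cc1` is not yet measured. It differs from compound 1 in one place: (4-methylphenyl)amino in place of 4-methylpiperazin-1-yl on an aromatic carbon. The shared core and the benzamide arm are unchanged.

Within the data shown here, no measured step of this kind exists in the set. Among the measured compounds shown here, compound 2 is the only compound carrying an arylamino group at the core, and a fall from compound 1 is expected because compound 2 gives 12.9% in this assay. The size of that fall is uncertain: compound 2 also differs from compound 1 in its linker. The step expected from compound 1 to compound 3 is a number 31.6 percentage points lower from compound 1 to compound 3 (beyond the scatter), a loss beyond the scatter. Compound 3 is estimated at 40%, with a range from 15% to 68%.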

Compound 3, a percentage reported as inhibition, at one concentration (the size of the read-out at that concentration, not a potency): 76.3%
Estimate against measurement, compound 3: 36.3 percentage points below; the measured number lies above the stated range.
By their numbers in this assay, from the lowest: compound 2; then compounds 1 and 3 (each within the scatter of the next).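

In this assay, among these compounds, the step of a number 4.7 percentage points higher from compound 1 to compound 3 (within the scatter) gives the first single-place reading at this position, with (4-methylphenyl)amino in place of 4-methylpiperazin-1-yl on an aromatic carbon. With the benzamide arm in place, this position therefore takes either a six-membered non-aromatic ring with 2 hetero atoms or a six-membered aromatic ring of carbon only joined through an amino nitrogen, and this single-concentration read-out does not separate the two. No measured evidence bears on why the two groups read alike.

As far as these compounds go, compound 2 differs from compound 1 and from compound 3 in more than one place, so its steps cannot be read, and the separate contributions of its linker and its arylamino group stay open. Also open, from the compounds shown here alone, is whether this result extends to other groups at this position, such as a morpholine ring, a simple alkylamine or a phenylamino group bearing a carboxylic acid, and whether compound 1 and compound 3 would still read alike as full potency measurements rather than at one concentration.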